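Ring for chain on the benzofuran core: a cytotoxicity forecast

This account rests on a few compounds, and the source may have more. Where it says the series, first, only, none or still open, it means among the compounds named here.

The series rests on three measured compounds. Compound 1 `CC(C)NC(=N)c1ccc2oc(-c3cccc(OCCCCCCOc4ccccc4)c3)cc2c1` carries a six-atom open-chain group on an aromatic carbon of its core; in an ADME assay on L6 cells (Rattus norvegicus) for cytotoxicity, read by resazurin assay, with a stated time of 70 h (on this read-out higher numbers stand for weaker inhibition and lower numbers for stronger inhibition), compound 1 gives 7400 nM. Compound 2 `c1ccc(OCCCCCCOc2cccc(-c3cc4cc(C5=NCCN5)ccc4o3)c2)cc1` has the same core but with a five-membered non-aromatic ring with 2 hetero atoms in that place (a group of 5 heavy atoms (3 carbon, 2 nitrogen; one five-membered non-aromatic ring with 2 hetero atoms) in place of a group of 6 heavy atoms (4 carbon, 2 nitrogen; no ring), on an aromatic carbon), and in this assay compound 2 gives 2500 nM. The step of a 3.0-fold lower number from compound 1 to compound 2 (0.47 log units; beyond the scatter) is therefore a move toward stronger inhibition. Compound 3 `CC(C)NC(=N)c1ccc2cc(-c3cccc(OCCCCCOc4ccccc4)c3)oc2c1` keeps the open-chain group of compound 1 on a different core; the difference between the two cores is not broken down here. In this assay compound 3 gives 20100 nM, the highest of the three numbers.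

Compound 4 `c1ccc(OCCCCCOc2cccc(-c3cc4ccc(C5=NCCN5)cc4o3)c2)cc1` is compound 3 with the same change a group of 5 heavy atoms (3 carbon, 2 nitrogen; one five-membered non-aromatic ring with 2 hetero atoms) in place of a group of 6 heavy atoms (4 carbon, 2 nitrogen; no ring), on an aromatic carbon that turned compound 1 into compound 2; the place description matches word for word, so the change is regarded as the same. Within the data shown here, only one earlier instance exists, so the forecast leans on it alone. For compound 4 the step of a 2.9-fold lower number from compound 3 to compound 4 (0.46 log units; beyond the scatter) is expected, because a 3.0-fold lower number from compound 1 to compound 2 (0.47 log units; beyond the scatter) shows the ring lowering the number. Compound 4 is thus estimated at 7000 nM in this assay, with a likely range of 3500 nM to 14000 nM.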

Compound 4, half-maximal inhibitory concentration: 3700 nM
Compound 4: the middle estimate sits 1.9-fold (0.28 log units) above what was measured; low and high end bracket the measured number.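

In this assay the ring again gives the lower number, with a 5.4-fold lower number from compound 3 to compound 4 (0.73 log units; beyond the scatter), so the change runs the same way on both cores and the two steps agree in size as closely as such data can tell: the same change on two cores in this assay, a 3.0-fold lower number (0.47 log units; beyond the scatter) from compound 1 to compound 2 and a 5.4-fold lower number (0.73 log units; beyond the scatter) from compound 3 to compound 4, 1.8-fold (0.26 log units) apart, within the scatter of two such steps

For these two pairs, then, putting the five-membered non-aromatic ring with 2 hetero atoms in place of the open-chain group carries over from one core to the other, and the gap between the steps gives no ground for saying that the core alters the result. This does not show that the change would behave alike on a further core, for two pairs are a slender base and their long ether chains also differ in length, nor does it explain why the number falls.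

The compounds shown leave open whether other groups on that aromatic carbon, such as a simple amine, a carboxylic acid or a six-membered cyclic amidine, would move the number in the same way. They also leave open whether a longer chain would change the size of the step, and whether the step would hold in any other read-out.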